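Working notes: tert-butyl in place of dimethylamino

A few compounds are considered here, and "the series" means these few. Any claim that something is new, unique, unknown or untested is made for them only; others in the source may bear on it.

Values measured in a functional assay on KB-V1 cells (Homo sapiens) for cytotoxicity, read by MTT assay, with a stated time of 72 h (a higher number here means a weaker inhibitor, a lower number a stronger inhibitor), follow
Compound 1 (`O=C1Nc2ccccc2/C1=N/NC(=S)Nc1cccnc1`) : > 50000 nM (a limit of the assay, not a number)
Compound 2 (`O=C1Nc2ccccc2/C1=N/NC(=S)Nc1c(F)cc(F)cc1F`) : 7280 nM
Compound 3 (`CN(C)c1ccc(NC(=S)N/N=C2\C(=O)Nc3ccccc32)cc1`) : 2320 nM

Compound 1 gives only a limit (the limit of > 50000 nM in this assay, at which 1 of the 3 values shown sits). Compound 3 holds the lowest number in this assay and its gap to compound 2 lies beyond the scatter. Compound 4 (`CC(C)(C)c1ccc(NC(=S)N/N=C2\C(=O)Nc3ccccc32)cc1`) keeps the shared core and carries tert-butyl in place of dimethylamino on an aromatic carbon, para to a large group (tert-butyl in place of dimethylamino on an aromatic carbon). Within the data shown here, no measured pair isolates this change, so no step beyond the scatter is expected in this assay for it. The expectation therefore stays close to compound 3 at 2320 nM with a wide range. The estimated change is a 1.1-fold lower number from compound 3 to compound 4 (0.02 log units; within the scatter) for this swap. For compound 4 the expected value is 2200 nM with an estimated range of 650 nM to 7500 nM in this series.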

Compound 4, half-maximal inhibitory concentration: 710 nM
Compound 4: middle estimate off by 3.1-fold (0.49 log units), on the high side, and the stated range covers the measured number.
By their numbers in this assay, from the lowest: compound 4; then compound 3; then compound 2. At a limit, above all of these: compound 1.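

In this assay, among these compounds, tert-butyl in place of dimethylamino, on an aromatic carbon para to a large group, gives a 3.3-fold lower number from compound 3 to compound 4 (0.51 log units; beyond the scatter), the only step here that isolates one place. This position therefore responds to the group it carries, and the dimethylamino nitrogen with its hydrogen-bond acceptor is not required for the lower number. No measured property shown bears on the reason for this step.

Still open, on these data alone, is how a carboxylic acid, a primary amine or a longer alkyl chain at this position would compare. Also open, as far as these compounds go, is whether the same swap gives a similar step on another aromatic ring.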